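Working notes on compounds 1 to 3: the dimethylcarbamoyl step

The source may report more compounds than this note shows. Statements on the series, on what has been measured and on what is new or still open speak of the compounds shown alone.

Measured compounds:
compound 1 `CC1(C)N=C(N)N=C(N)N1c1cccc(CNC(=O)Nc2cccc(Cl)c2)c1` — 8.05
compound 2 `COc1cccc(NC(=O)NCc2cccc(N3C(N)=NC(N)=NC3(C)C)c2)c1` — 8.02

In an assay on isolated protein for inhibition of Dihydrofolate reductase (Mus musculus) (on this read-out lower numbers stand for lower potency and higher numbers for higher potency (the scale is a negative logarithm)), compound 1 gives 8.05, and compound 2 gives 8.02. Compound 2 holds the lower of the two numbers shown, but only nominally: the step of a number 0.03 log units lower from compound 1 to compound 2 (within the scatter) lies within the scatter, so the pair cannot be ranked. Compound 3 `CN(C)C(=O)c1cccc(NC(=O)NCc2cccc(N3C(N)=NC(N)=NC3(C)C)c2)c1` is not yet measured. Its difference from compound 2 is dimethylcarbamoyl in place of methoxy on an aromatic carbon. Within the data shown here, the only measured step at this position, a number 0.03 log units lower from compound 1 to compound 2 (within the scatter), was flat, and it exchanged two groups unlike the one now entering, so it offers limited guidance. With nothing in the data showing that this position moves the read-out, compound 3 is expected to sit close to compound 2, the estimated step being a number 0.22 log units lower from compound 2 to compound 3 (within the scatter), not clearly beyond the scatter. Compound 3 is therefore estimated at 7.8, with a range from 7.2 to 8.4.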

Compound 3, logarithm of the reciprocal of the active concentration, log(1/C): 7.77
Compound 3: middle estimate off by 0.03 log units, on the high side, and the stated range covers the measured number.
By their numbers in this assay, from the lowest: compounds 3, 2 and 1 (each within the scatter of the next).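

The exchange of methoxy for dimethylcarbamoyl, with 5 heavy atoms against 2, on an aromatic carbon meta to a large group gives, in this assay, a number 0.25 log units lower from compound 2 to compound 3 (within the scatter), and the exchange of chloro for the same group gives a number 0.28 log units lower from compound 1 to compound 3 (within the scatter). Neither step leaves the scatter, so this position now holds three groups, including one with a carbonyl and a clearly larger heavy-atom count, and the three compounds still cannot be ranked. No supporting data bear on why the read-out stays flat at this position.

From the compounds shown here alone, whether an amine, a carboxylic acid or a longer chain at this position would move the read-out beyond the scatter remains open. Going by these compounds, how far this flat behaviour extends to changes elsewhere on the shared core also remains open.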